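Triazole ester analogues and cytotoxicity toward lung cells

The compounds below may be only part of what the source reports. "The series", "measured", "known", "first", "only" and "open" are said of these compounds alone.

Compound 1 `COc1ccccc1-n1cc(COC(=O)/C(C)=C/CC/C(C)=C/CC/C(C)=C/CC[C@@H]2[C@@]3(C)CCC(=O)C(C)(C)[C@H]3CC[C@@]2(C)O)nn1`: in an ADME assay on L132 cells (Homo sapiens) for cytotoxicity, read by MTT assay, with a stated time of 48 h (on this read-out lower numbers stand for stronger inhibition and higher numbers for weaker inhibition), compound 1 gives > 150000 nM, which is a limit of the assay, not a number.
Compound 2 `C/C(=C\CC/C(C)=C/CC[C@@H]1[C@@]2(C)CCC(=O)C(C)(C)[C@H]2CC[C@@]1(C)O)CC/C=C(\C)C(=O)OCc1cn(-c2ccccc2C)nn1`: compound 2 gives > 150000 nM, again a limit.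
Compound 3 `COc1ccc(-n2cc(COC(=O)/C(C)=C/CC/C(C)=C/CC/C(C)=C/CC[C@@H]3[C@@]4(C)CCC(=O)C(C)(C)[C@H]4CC[C@@]3(C)O)nn2)cc1`: compound 3 gives > 150000 nM, again a limit.

Compound 1 therefore stands only at a limit, and the two other values shown share that limit (the limit of > 150000 nM in this assay, at which 3 of the 3 values shown sit). Compound 4 `C/C(=C\CC/C(C)=C/CC[C@@H]1[C@@]2(C)CCC(=O)C(C)(C)[C@H]2CC[C@@]1(C)O)CC/C=C(\C)C(=O)OCc1cn(-c2cccc(Cl)c2)nn1` differs from compound 1 by 3-chlorophenyl in place of 2-methoxyphenyl on an aromatic nitrogen. Among the compounds with values here, the steps that bear on this change, a step that the two limits leave unreadable from compound 1 to compound 2, a step that the two limits leave unreadable from compound 1 to compound 3 and a step that the two limits leave unreadable from compound 2 to compound 3, cannot be read, since both ends of each are limits. No step beyond the scatter is therefore expected in this assay, and the expected step is a step that the limit leaves unreadable from compound 1 to compound 4. Compound 4 is estimated at 200000 nM, within 100000 nM to 400000 nM, most likely reported again as a limit.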

Compound 4, half-maximal inhibitory concentration: 94200 nM
Beside the measured number, compound 4's estimate is 2.1-fold (0.33 log units) above it, and the stated range ends above it.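

Within the data shown here, compound 4 is the first compound here to give a true number rather than a limit in this assay and so makes steps at this aromatic nitrogen readable for the first time: an at least 1.5-fold lower number from compound 1 to compound 4 (0.20 log units; that floor lies within the scatter) and an at least 1.5-fold lower number from compound 3 to compound 4 (0.20 log units; that floor lies within the scatter) and an at least 1.5-fold lower number from compound 2 to compound 4 (0.20 log units; that floor lies within the scatter) as well. Among these compounds, each is only a floor, so 3-chlorophenyl cannot yet be said to differ from the other aryl groups, and the steps among the earlier compounds cannot be read. The other compounds all stop at one limit: the limit of > 150000 nM in this assay, at which 3 of the 4 values shown sit.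

On these data alone, whether the chlorine itself matters stays open, as does what a bromine or an amine in its place would give.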